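Compound 3 to compound 4: losing the isopropyl group

The source may hold more compounds than are shown below. What is called first, only, known or untested is meant among the compounds shown, and "the series" means these compounds.

In a functional assay on HepG2 cells (Homo sapiens) for antiproliferative activity, read by MTT assay, with a stated time of 72 h (a higher number here means a weaker inhibitor, a lower number a stronger inhibitor), compound 1 `COc1cccc(N2C(=O)COc3ccc(-c4cnc(Cl)c(NS(=O)(=O)c5ccc(F)cc5)c4)cc32)c1` gives > 40000 nM, which is a limit of the assay and not a number. Compound 2 `O=C1COc2ccc(-c3cnc(Cl)c(NS(=O)(=O)c4ccc(F)cc4)c3)cc2N1C1CCCCC1` gives > 40000 nM, which is also a limit. Going by the values given here, compound 3 `CC(C)N1C(=O)COc2ccc(-c3cnc(Cl)c(NS(=O)(=O)c4ccc(F)cc4)c3)cc21` gives 21500 nM, the only actual number among the three.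

Compound 4 `O=C1COc2ccc(-c3cnc(Cl)c(NS(=O)(=O)c4ccc(F)cc4)c3)cc2N1` differs from compound 3 as follows: hydrogen in place of isopropyl on an amide-type nitrogen in a ring. This places hydrogen in place of isopropyl on an amide-type nitrogen in a ring.

Two measured steps change the same substituent: an at least 1.8-fold lower number from compound 1 to compound 3 (0.26 log units; that floor lies within the scatter) and an at least 1.8-fold lower number from compound 2 to compound 3 (0.26 log units; that floor lies within the scatter). Both sizes are floors within the scatter, and a step that the two limits leave unreadable from compound 1 to compound 2 gives no size at all. Going by an at least 1.8-fold lower number from compound 2 to compound 3 (0.26 log units; that floor lies within the scatter), a slightly lower number in this assay is the expected direction, but no step beyond the scatter is expected.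

For compound 4 the estimated value is 16000 nM, with an expected range of 6000 nM to 38000 nM. The estimate corresponds to an expected 1.3-fold lower number from compound 3 to compound 4 (0.13 log units; within the scatter).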

Compound 4, half-maximal inhibitory concentration: > 40000 nM
Compound 4 ended at the assay's limit (the forecaster's own chance of this, stated with the estimate: 20%); at least 2.5-fold (0.39 log units) between middle value and limit.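

In this assay, hydrogen in place of isopropyl on the amide-type nitrogen gives an at least 1.8-fold higher number from compound 3 to compound 4 (0.26 log units; that floor lies within the scatter), so this step is readable only as a floor. Going by these compounds alone, compound 4 adds the case with no substituent on this nitrogen and ends at a limit of the assay, which leaves isopropyl as the only group here with an actual number. The steps to compound 4 from compound 1 and compound 2 cannot be read, because both ends of each are limits: the limit of > 40000 nM in this assay, at which 3 of the 4 values shown sit.

Open, going by these compounds, is whether a short chain such as ethyl, or a chain ending in an amine, on this nitrogen would give a number, and how that number would compare with compound 3 at 21500 nM. Also open, on these data alone, is whether changes elsewhere on the shared core would move values away from the limit.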